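The source may report more compounds than this note shows. Statements on the series, on what has been measured and on what is new or still open speak of the compounds shown alone.

In an ADME assay on L929 cells (Mus musculus) for cytotoxicity, read by resazurin assay, with a stated time of 48 h (on this read-out higher numbers stand for lower toxicity in this test and lower numbers for higher toxicity in this test), compound 2 (`O=C(O)CCCn1c2ccc([N+](=O)[O-])cc2c(=O)n1Cc1ccccc1`) gives > 256000 nM, which is a limit of the assay and not a number. Compound 2 therefore stands at the limit of > 256000 nM in this assay, at which 1 of the 2 values shown sits. Compound 1 (`O=c1c2cc([N+](=O)[O-])ccc2n(CCCBr)n1Cc1ccccc1`), which carries bromo at the chain end, gives 25200 nM. Among the measured compounds shown here, the one measured step is an at least 10-fold higher number from compound 1 to compound 2 (1.00 log units; beyond the scatter), and it is only a lower bound on the size of that change. Compound 3 (`CN(C)C(=O)CCCn1c2ccc([N+](=O)[O-])cc2c(=O)n1Cc1ccccc1`) differs from compound 2 by dimethylamino in place of hydroxy on a carbonyl carbon, with dimethylamino in place of hydroxy on a carbonyl carbon, so that carboxy becomes dimethylcarbamoyl. For the measured compounds named here, no measured step covers this change directly. Compound 3 has no bromo, so a value as low as that of compound 1 at 25200 nM is not expected. A number under the limit of compound 2 is nevertheless expected for compound 3. The expected change is an at least 2.1-fold lower number from compound 2 to compound 3 (0.32 log units; beyond the scatter), a modest move towards lower numbers in this assay. For compound 3 the estimate is 120000 nM, with an expected range of 35000 nM to 256000 nM.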

Compound 3, concentration lethal to 50% of the cells: > 256000 nM
Compound 3: a limit, no number; the forecaster's own chance of this, stated with the estimate: 35%; middle value at least 2.1-fold (0.32 log units) from the limit.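

In this assay, carboxy is not the only chain end that leaves the bromo result behind, for dimethylcarbamoyl in place of bromo gives an at least 10-fold higher number from compound 1 to compound 3 (1.00 log units; beyond the scatter). The step between compound 2 and compound 3 cannot be read, since both stand at a limit, so the exchange of hydroxy for dimethylamino on the carbonyl carbon has no measurable size here. The carboxy and dimethylcarbamoyl chain ends now share the upper end of the scale: the limit of > 256000 nM in this assay, at which 2 of the 3 values shown sit.

Still open, going by these compounds, is whether the low number of compound 1 belongs to bromo alone, or whether an amine or a simple hydroxy at the end of the same chain would also fall under that limit. A longer chain carrying carboxy or dimethylcarbamoyl could show whether the chain length matters as well.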